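Swapping Bromine for Methoxy on a Weak Growth Inhibitor

The source may report more compounds than this note shows. Statements on the series, on what has been measured and on what is new or still open speak of the compounds shown alone.

Compound 1 `COc1ccc(C2=C(c3ccc(SC)cc3)CC3CCCN3C2=O)cc1Br` is the weaker of the two measured compounds in a functional assay on M14 cells (Homo sapiens) for cytotoxicity (a higher number here means a weaker inhibitor of growth, a lower number a stronger inhibitor of growth), where compound 1 gives 3000 nM. Going by the values given here, compound 2 `CSc1ccc(C2=C(c3ccc(F)c(F)c3)C(=O)N3CCCC3C2)cc1` gives 300 nM, and the one measured step, a 10-fold lower number from compound 1 to compound 2 (1.00 log units; beyond the scatter), replaces the whole aryl ring rather than a single group on it. Compound 3 `COc1ccc(C2=C(c3ccc(SC)cc3)CC3CCCN3C2=O)cc1OC` differs from compound 1 by methoxy in place of bromo on an aromatic carbon. That measured step bears only loosely on this smaller change, so no step beyond the scatter is expected in this assay. Compound 3 is expected to give 3000 nM, within 1000 nM to 10000 nM. The expected step is no change at the digits printed from compound 1 to compound 3 (within the scatter).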

Compound 3, concentration for 50% growth inhibition: 5000 nM
The estimate for compound 3 lay 1.7-fold (0.22 log units) below the measured number; low and high end bracket the measured number.
By their numbers in this assay, from the lowest: compound 2; then compounds 1 and 3 (each within the scatter of the next).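

In this assay methoxy in place of bromo on this aromatic carbon gives a 1.7-fold higher number from compound 1 to compound 3 (0.22 log units; within the scatter) and so, unlike the replacement of the whole ring in compound 2, makes no readable difference. On this evidence, bromo and methoxy cannot be told apart at this position, although they differ in size and in hydrogen-bond acceptors. Nothing available gives a reason for this result. Going by these compounds, whether an amine or a carboxylic acid on the same carbon would also leave the number unmoved remains open. So does which fluorine of the 3,4-difluorophenyl ring matters for the lower number of compound 2.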